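This account rests on a few compounds, and the source may have more. Where it says the series, first, only, none or still open, it means among the compounds named here.

Of the compounds shown here, two of this set have been measured in a functional assay on SMMC-7721 cells (Homo sapiens) for cytotoxicity, read by MTT assay, with a stated time of 72 h; on this read-out lower numbers stand for stronger inhibition and higher numbers for weaker inhibition. Compound 1 `COc1cc(C=C2C(=O)N(c3ccc(Cl)cc3)N(c3ccc(Cl)cc3)C2=O)cc(OC)c1OC` gives 29500 nM. Compound 2 `COc1ccc(C=C2C(=O)N(c3ccc(Cl)cc3)N(c3ccc(Cl)cc3)C2=O)cc1` is known only by a limit of the assay, as the limit of > 128000 nM in this assay, at which 1 of the 2 values shown sits, shows; in this assay compound 2 gives > 128000 nM, a limit and not a number. The next compound, compound 3 `O=C1C(=Cc2ccco2)C(=O)N(c2ccc(Cl)cc2)N1c1ccc(Cl)cc1`, differs from compound 2 by furan-2-yl in place of 4-methoxyphenyl on a double-bonded chain carbon bound to a double-bonded ring carbon. No step between measured compounds is shown, so the expected step from compound 2 to compound 3 is set as an at least 1.2-fold lower number from compound 2 to compound 3 (0.10 log units; that floor lies within the scatter), a modest change whose direction is uncertain. For compound 3 the estimate is 100000 nM, within 30000 nM to 250000 nM.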

Compound 3, half-maximal inhibitory concentration: 19500 nM
Compound 3: middle estimate off by 5.1-fold (0.71 log units), on the high side; the measured number lies below the stated range.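

Placed on a double-bonded chain carbon bound to a double-bonded ring carbon, furan-2-yl in place of 4-methoxyphenyl gives the first readable step at this position in this assay, with an at least 6.5-fold lower number from compound 2 to compound 3 (0.81 log units; beyond the scatter), so this place does respond to a change of ring. That step is a floor and not a full size. Compound 2 is known only by a limit: the limit of > 128000 nM in this assay, at which 1 of the 3 values shown sits. The compounds shown leave open whether a thiophene, a pyridine or a plain phenyl ring at this place would act like furan-2-yl.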